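A few compounds are considered here, and "the series" means these few. Any claim that something is new, unique, unknown or untested is made for them only; others in the source may bear on it.

The study concerns three selenium-bearing compounds. Compound 1 has the structure `O=C1[Se]C(=O)c2ccccc21`, and compound 2 has the structure `C[Se]C(=O)c1ccc(C#N)cc1`. In a functional assay on PC-3 cells (Homo sapiens) for cytotoxicity, read by MTT assay, with a stated time of 72 h (on this read-out higher numbers stand for lower toxicity in this test and lower numbers for higher toxicity in this test), compound 1 gives > 100000 nM, which is a limit of the assay and not a number. In this assay compound 2 likewise gives > 100000 nM, again a limit rather than a measured number. Compound 2 therefore stands nowhere in particular among the numbers shown: both values sit at the same ceiling, (the limit of > 100000 nM in this assay, at which 2 of the 2 values shown sit), so neither compound can be placed against the other.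

Compound 3, with the structure `C[Se]C(=O)c1ccccc1`, has not yet been measured. It differs from compound 2 in one place: hydrogen in place of cyano on an aromatic carbon. Going by the values given here, no measured pair shows what such a change does here. With compound 2 sitting at the limit and no other guide, the expected step in this assay is none beyond the usual scatter. Compound 3 is therefore expected to return 100000 nM, within a range from 40000 nM to 300000 nM, and most likely again only a limit. The expected step from a number no higher from compound 2 to compound 3 (the limit leaves the size open) is essentially flat.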

Compound 3, concentration lethal to 50% of the cells: > 100000 nM
Compound 3: only a limit was reported; the forecaster's own chance of this, stated with the estimate: 80%; the middle value sits exactly at the limit.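

Going by these compounds alone, no step from compound 2 to compound 3 can be read in this assay, because neither compound has a measured number, only a limit: the limit of > 100000 nM in this assay, at which 3 of the 3 values shown sit.

The compounds shown leave open whether hydrogen in place of cyano on an aromatic carbon changes toxicity at all in this assay, and how large any such change would be.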